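Working notes: tert-butyl in place of ethyl

The source may hold more compounds than are shown below. What is called first, only, known or untested is meant among the compounds shown, and "the series" means these compounds.

compound 1 `CC1CCC(C(C)C)C(OC(=O)C#CC(O/C=C/C(=O)OC2CC(C)CCC2C(C)C)C(C)C)C1` gives > 100000 nM (a limit)
compound 2 `COC(=O)C#CC(O/C=C/C(=O)OC)C(C)c1ccccc1` gives 1200 nM
compound 3 `CCC(C#CC(=O)OC)O/C=C/C(=O)OC` gives 540 nM

In a functional assay on SW1573 cells (Homo sapiens) for antiproliferative activity, read by sulforhodamine B assay, with a stated time of 48 h (on this read-out lower numbers stand for stronger inhibition of growth and higher numbers for weaker inhibition of growth), compound 3 gives 540 nM, the lower of the two actual numbers. Compound 1 stands at a limit of the assay, > 100000 nM. Compound 4 `COC(=O)C#CC(O/C=C/C(=O)OC)C(C)(C)C` differs from compound 3 by tert-butyl in place of ethyl on a saturated chain carbon bound to an oxygen on an unsaturated carbon and a triple-bonded carbon. Going by the values given here, no measured step changes this group directly. The closest evidence is a 2.2-fold lower number from compound 2 to compound 3 (0.35 log units; beyond the scatter), with hydrogen in place of phenyl on a saturated chain carbon bound to two saturated chain carbons. That single step is modest but beyond the scatter, and the compound with the larger group has the higher number. A similarly modest move to a higher number is therefore expected in this assay, though with wide uncertainty. The expected step is a 1.7-fold higher number from compound 3 to compound 4 (0.22 log units; within the scatter). Compound 4 is estimated at 900 nM, with an expected range of 300 nM to 3000 nM.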

Compound 4, concentration for 50% growth inhibition: 3000 nM
For compound 4 the middle estimate is 3.3-fold (0.52 log units) below the measured one; the measured number falls inside the stated range.
By their numbers in this assay, from the lowest: compound 3; then compound 2; then compound 4. At a limit, above all of these: compound 1.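

In this assay, the position on the saturated chain carbon bound to an oxygen on an unsaturated carbon and a triple-bonded carbon now has a direct measured step, and tert-butyl in place of ethyl gives the change (a 5.6-fold higher number from compound 3 to compound 4 (0.74 log units; beyond the scatter)). The position therefore does not tolerate every carbon group equally, and the step lies beyond the scatter, whereas the earlier step (a 2.2-fold lower number from compound 2 to compound 3 (0.35 log units; beyond the scatter)) was made on a carbon further along that side chain. Nothing shown bears on the cause of the new step.

Open, going by these compounds, is how an unbranched n-butyl chain would read at this position, which would set chain length apart from branching. Also open, on these data alone, is how a group carrying an amine or a carboxylic acid would read there.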